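This account rests on a few compounds, and the source may have more. Where it says the series, first, only, none or still open, it means among the compounds named here.

Of the compounds shown here, two have been tested so far in a functional assay on MIA PaCa-2 cells (Homo sapiens) for inhibition, read by MTT assay, with a stated time of 48 h, tested at 10 uM; a higher number here means more inhibition of growth at the concentration tested, a lower number less inhibition of growth. Compound 1, with the structure `O=C(/C=C/c1ccc(OCc2cn(Cc3ccccc3F)nn2)cc1)c1ccc(Br)cc1`, gives 28%. Compound 2, with the structure `COc1ccc(C(=O)/C=C/c2ccc(OCc3cn(Cc4cccc(Br)c4)nn3)cc2)cc1`, gives 50%. Compound 2 thus stands highest of the two numbers, and its gap to compound 1 lies beyond the usual scatter of such measurements. The two compounds differ in two places at once, so neither difference can be tied to the gap on its own.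

Compound 3, with the structure `COc1ccc(C(=O)/C=C/c2ccc(OCc3cn(Cc4ccccc4F)nn3)cc2)cc1`, has not yet been measured. It differs from compound 2 in one place: 2-fluorophenyl in place of 3-bromophenyl on a saturated chain carbon bound to an aromatic nitrogen. Compound 3 therefore carries the same 2-fluorobenzyl group as compound 1, while keeping the rest of compound 2 unchanged. Since compound 1 gives 28% and compound 2 gives 50%, a value between the two seems the reasonable expectation for compound 3, meaning a modest downward step that may not clearly exceed the scatter. The expected step from compound 2 to compound 3 is a number 10 percentage points lower from compound 2 to compound 3 (within the scatter). Compound 3 is estimated to give 40% in this assay, with a range from 22% to 58%.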

Compound 3, percent growth inhibition at one concentration: 19%
Compound 3: middle estimate off by 21 percentage points, on the high side; measured number outside the range, below it.
By their numbers in this assay, from the lowest: compounds 3 and 1 (each within the scatter of the next); then compound 2.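

Within this assay and with the methoxy group kept in place, 2-fluorophenyl in place of 3-bromophenyl on a saturated chain carbon bound to an aromatic nitrogen gives a number 31 percentage points lower from compound 2 to compound 3 (beyond the scatter), so the group at this place can strongly alter the read-out, at least in this pair. With the 2-fluorobenzyl group kept instead, methoxy in place of bromo on an aromatic carbon gives a number 9 percentage points lower from compound 1 to compound 3 (within the scatter), so this pair shows no clear effect of that exchange. Nothing measured here offers a reason for the large step seen with the benzyl change.

This single benzyl change alters both the halogen and its place on the ring, so the compounds shown cannot say which of the two matters; 3-fluorophenyl or 2-bromophenyl at the same place would pull them apart. Also open, from the compounds shown here alone, are whether the methoxy and bromo exchange stays as small when the 3-bromobenzyl group is present, and how a plain phenyl or a ring carrying an amine would compare at this place.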